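The compounds below may be only part of what the source reports. "The series", "measured", "known", "first", "only" and "open" are said of these compounds alone.

Values in an in vitro ADME assay on microsomes from liver (Homo sapiens) for metabolic stability; a lower number here means slower removal, a higher number faster removal of the compound:
- compound 1 `O=C(Nc1cccnc1-c1ccsc1)N1CCN2C(=O)N([C@H]3C[C@@H]3c3ccccc3)C(=O)[C@@H]2C1`: 40000 mL.min-1.g-1
- compound 2 `O=C(Nc1cccnc1-c1cccc(Cl)c1)N1CCN2C(=O)N([C@H]3C[C@@H]3c3ccccc3)C(=O)[C@@H]2C1`: 90000 mL.min-1.g-1

Of these two numbers, compound 1 has the lower, at 40000 mL.min-1.g-1. Compound 3 `O=C(Nc1cccc(Cl)c1Cl)N1CCN2C(=O)N([C@H]3C[C@@H]3c3ccccc3)C(=O)[C@@H]2C1` differs from it by 2,3-dichlorophenyl in place of 2-(thiophen-3-yl)pyridin-3-yl on an amide-type nitrogen. Going by the values given here, no measured step covers a change on the amide-type nitrogen. The nearest guide is a 2.3-fold higher number from compound 1 to compound 2 (0.35 log units; beyond the scatter), a modest step beyond the scatter, with 3-chlorophenyl in place of thiophen-3-yl on an aromatic carbon. A modest move in this assay towards a higher number is therefore expected, and the expected step is a 1.8-fold higher number from compound 1 to compound 3 (0.24 log units; within the scatter). Compound 3 is estimated at 70000 mL.min-1.g-1, within an expected range of 25000 mL.min-1.g-1 to 180000 mL.min-1.g-1.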

Compound 3, intrinsic clearance in microsomes: 73000 mL.min-1.g-1
Compound 3: middle estimate off by 1.0-fold (0.02 log units), on the low side, within the range that was stated.
By their numbers in this assay, from the lowest: compounds 1, 3 and 2 (each within the scatter of the next, the first and the last beyond it).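

In this assay, putting 2,3-dichlorophenyl in place of 2-(thiophen-3-yl)pyridin-3-yl on the amide-type nitrogen gives a 1.8-fold higher number from compound 1 to compound 3 (0.26 log units; within the scatter). Going by these compounds alone, this is the first reading at this position, and a change that drops the five-membered aromatic ring, the ring nitrogen and the sulfur, and brings in two chlorines, stays within the scatter. No measurement here offers an explanation for this result.

Still open, on these data alone, is whether a carboxylic acid or an amine on the aromatic ring at this nitrogen would give a step beyond the scatter. Also open, as far as these compounds go, is whether an unsubstituted phenyl there would stay within it.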